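Replacing 1,3-oxazol-2-yl with 3-fluorophenyl in Compound 2

A few compounds are considered here, and "the series" means these few. Any claim that something is new, unique, unknown or untested is made for them only; others in the source may bear on it.

Compound 1 `Cc1ccc(-c2nc(N)c3cc(Cc4ccccc4F)sc3n2)o1` — < 16 nM in a functional assay on CHO-K1 cells for antagonist activity at adenosine receptor A1 (Homo sapiens), read by a beta-galactosidase reporter and cAMP accumulation, with stated times of 15 min and 6 h (a higher number here means a weaker inhibitor, a lower number a stronger inhibitor), a limit of the assay.
Compound 2 `Nc1nc(-c2ncco2)nc2sc(Cc3ccccc3)cc12` — 310 nM in this assay.
Compound 3 `COc1ccccc1Cc1cc2c(N)nc(-c3nc(C)cs3)nc2s1` — 186 nM in this assay.

Three compounds share a core and carry different groups on it. For compound 1 the assay reports only a limit, (the limit of < 16 nM in this assay, at which 1 of the 3 values shown sits). Of the two numbers actually reported, compound 2 has the higher one, but compound 3 sits within the usual scatter of it, so the two cannot be told apart on these data.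

Compound 4 `Nc1nc(-c2cccc(F)c2)nc2sc(Cc3ccccc3)cc12` has not yet been measured. It differs from compound 2 in one place: 3-fluorophenyl in place of 1,3-oxazol-2-yl on an aromatic carbon. Within the data shown here, no measured pair here isolates this kind of exchange, so the size of the step must be judged without a direct precedent. Among the measured compounds shown here, the account expects a moderate shift toward a lower number, not far beyond the scatter, since compound 1, the only compound here with a carbon-rich aromatic group in that place, reaches the assay limit.

For compound 4 the estimate is 140 nM, with a range from 40 nM to 500 nM. This estimate implies an expected step of a 2.2-fold lower number from compound 2 to compound 4 (0.35 log units; beyond the scatter).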

Compound 4, inhibition constant: 123 nM
The estimate for compound 4 lay 1.1-fold (0.06 log units) above the measured number; measured number inside the range.
By their numbers in this assay, from the lowest: compounds 4, 3 and 2 (each within the scatter of the next, the first and the last beyond it). At a limit, below all of these: compound 1.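

The exchange is the only one shown that isolates this position, the aromatic carbon between two ring nitrogen atoms, and in this assay 3-fluorophenyl in place of 1,3-oxazol-2-yl gives a 2.5-fold lower number from compound 2 to compound 4 (0.40 log units; beyond the scatter). The place therefore accepts a six-membered aromatic ring of carbon only, and the two hydrogen-bond acceptors counted on the group that leaves are not required for a value of this size. The step rests on a single pair, and nothing measured here gives a cause for it.

The compounds shown leave open what the fluorine itself adds, for which a plain phenyl group at this place would be the direct comparison, and how an amine or a longer alkyl chain would fare there. Compound 1 differs from compound 4 in more than one place and gives only a limit, so it fixes no step at this position: the limit of < 16 nM in this assay, at which 1 of the 4 values shown sits.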